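Swapping the aryl group on the amide nitrogen

This account rests on a few compounds, and the source may have more. Where it says the series, first, only, none or still open, it means among the compounds named here.

Compound 1 `COc1cc2c(cc1OC)C(CC(=O)Nc1cccc(Cl)c1)CC2`: 25.8%
Compound 2 `COc1cc2c(cc1OC)C(CC(=O)Nc1ccc(Br)cc1)CC2`: 40.6%
Compound 3 `COc1cc2c(cc1OC)C(CC(=O)Nc1cccc(C)c1)CC2`: 40.6%

Three compounds sharing one core were tested in a functional assay on the whole organism (strain Wistar) for inhibition, with Rattus norvegicus as the target, read by paw edema, with a stated time of 4 h, at a dose of 100 mg/kg; on this read-out higher numbers stand for more inhibition at the one dose given (going by the name of the read-out) and lower numbers for less inhibition. Compound 3 sits level with compound 2, the two together being the highest of the three numbers; the step of a number 14.8 percentage points higher from compound 1 to compound 3 (beyond the scatter) lies beyond the scatter, whereas no change at the digits printed from compound 2 to compound 3 (within the scatter) lies within it.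

Compound 4 `COc1ccccc1NC(=O)CC1CCc2cc(OC)c(OC)cc21` differs from compound 3 by 2-methoxyphenyl in place of 3-methylphenyl on an amide-type nitrogen. Among the measured compounds shown here, no measured step makes this particular exchange. The two steps that do alter the aryl group on the amide nitrogen, a number 14.8 percentage points higher from compound 1 to compound 2 (beyond the scatter) and no change at the digits printed from compound 2 to compound 3 (within the scatter), show a modest rise in the number and no change, so the number stays higher or level across these changes. For compound 4 a step no larger than the scatter is expected, leaning slightly downward: a number 6.6 percentage points lower from compound 3 to compound 4 (within the scatter). Compound 4 is therefore estimated at 34%, ranging from 18% to 50%.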

Compound 4, a percentage reported as inhibition, in the whole organism at one dose (the size of the read-out at that dose, not a potency): 23.4%
Beside the measured number, compound 4's estimate is 10.6 percentage points above it; measured number inside the range.
By their numbers in this assay, from the lowest: compounds 4 and 1 (each within the scatter of the next); then compounds 2 and 3 (each within the scatter of the next).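

On the amide-type nitrogen, 2-methoxyphenyl gives a clear fall that the earlier exchanges among 4-bromophenyl and 3-methylphenyl did not show (a number 17.2 percentage points lower from compound 3 to compound 4 (beyond the scatter); a number 17.2 percentage points lower from compound 2 to compound 4 (beyond the scatter)). Its step from 3-chlorophenyl stays within the scatter (a number 2.4 percentage points lower from compound 1 to compound 4 (within the scatter)), so compound 1 and compound 4 cannot be told apart at this position. Nothing available explains these differences.

From the compounds shown here alone, whether an unsubstituted phenyl would sit with compound 3 or with compound 4 stays open. So does the effect of an amine or a carboxylic acid on this aryl group.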